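The source may report more compounds than this note shows. Statements on the series, on what has been measured and on what is new or still open speak of the compounds shown alone.

Measured in a functional assay on HepG2 cells (Homo sapiens) for cytotoxicity, read by MTT assay; a higher number here means a weaker inhibitor, a lower number a stronger inhibitor:
- Compound 1 `C=C1C(=O)[C@]23C[C@@]1(F)CC[C@H]2[C@@]12C=CC(=O)[C@](C)(C(=O)O1)[C@H]2[C@@H]3C(=O)OCc1ccccc1`: 44100 nM
- Compound 2 `C=C1C(=O)[C@]23C[C@@]1(I)CC[C@H]2[C@@]12C=CC(=O)[C@](C)(C(=O)O1)[C@H]2[C@@H]3C(=O)OCc1ccccc1`: 69500 nM
- Compound 3 `C=C1C(=O)[C@]23C[C@@]1(OC)CC[C@H]2[C@@]12C=CC(=O)[C@](C)(C(=O)O1)[C@H]2[C@@H]3C(=O)OC`: 43500 nM

All three values lie close together. Compound 3, at 43500 nM, is within the usual scatter of both compound 1 and compound 2, so it cannot be ranked against either.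

The next compound is compound 4 `C=C1C(=O)[C@]23C[C@@]1(OC)CC[C@H]2[C@@]12C=CC(=O)[C@](C)(C(=O)O1)[C@H]2[C@@H]3C(=O)OCc1ccccc1`, made from compound 3 by one change: phenyl in place of hydrogen on a saturated chain carbon bound to an oxygen next to a carbonyl group. This puts phenyl in place of hydrogen on a saturated chain carbon bound to an oxygen next to a carbonyl group, which turns methoxycarbonyl into benzyloxycarbonyl. Going by the values given here, no measured step covers this exact change. Among the compounds with values here, the only measured step, a 1.6-fold higher number from compound 1 to compound 2 (0.20 log units; within the scatter), is a different swap, iodo in place of fluoro on a saturated ring carbon. Still, compound 1 and compound 2 already carry benzyloxycarbonyl, and compound 2 at 69500 nM stays within the scatter of compound 3.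

The expected result is therefore no shift beyond the scatter, in either direction, with an estimated 1.1-fold higher number from compound 3 to compound 4 (0.04 log units; within the scatter).

For compound 4 the estimated value is 48000 nM, with an expected range from 25000 nM to 90000 nM.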

Compound 4, half-maximal inhibitory concentration: 35000 nM
Estimate against measurement, compound 4: 1.4-fold (0.14 log units) above; the measured number falls inside the stated range.
By their numbers in this assay, from the lowest: compounds 4, 3, 1 and 2 (each within the scatter of the next).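

In this assay, adding phenyl on a saturated chain carbon bound to an oxygen next to a carbonyl group, which turns methoxycarbonyl into benzyloxycarbonyl, stays within the scatter (a 1.2-fold lower number from compound 3 to compound 4 (0.09 log units; within the scatter)), so at this position the four compounds give the first direct sign that this size of group leaves the reading unmoved. Compound 4 also shows that, with benzyloxycarbonyl kept, methoxy on the saturated ring carbon cannot be told apart from fluoro (a 1.3-fold lower number from compound 1 to compound 4 (0.10 log units; within the scatter)) or from iodo (a 2.0-fold lower number from compound 2 to compound 4 (0.30 log units; within the scatter)). No measurement offered here explains why these swaps leave the number in place.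

From the compounds shown here alone, it remains open whether an amine on the saturated ring carbon would shift the number beyond the scatter. The same question holds for a carboxylic acid in place of methoxycarbonyl or benzyloxycarbonyl.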